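Benzyl Ether Variation on a Shared Chromone Scaffold

The source may report more compounds than this note shows. Statements on the series, on what has been measured and on what is new or still open speak of the compounds shown alone.

Compound 2 `COc1cc(OC)c(-c2coc3cc(OCc4ccc(Cl)cc4)ccc3c2=O)cc1OC` is one of two measured compounds, and in a functional assay on B16 cells (Mus musculus) for antiproliferative activity, read by MTT assay, with a stated time of 24 h (a higher number here means a weaker inhibitor, a lower number a stronger inhibitor), compound 2 gives 2400 nM. Compound 1 `C#CCOc1ccc2c(=O)c(-c3cc(OC)c(OC)cc3OC)coc2c1` gives 4500 nM in this assay. Within the data shown here, the only measured step, a 1.9-fold lower number from compound 1 to compound 2 (0.27 log units; within the scatter), lies within the scatter, so compound 2 holds the lower of the two numbers without standing apart from compound 1. Compound 3 `COc1cc(OC)c(-c2coc3cc(OCc4cccc(C(F)(F)F)c4)ccc3c2=O)cc1OC` is not yet measured and differs from compound 2 by 3-(trifluoromethyl)phenyl in place of 4-chlorophenyl on a saturated chain carbon bound to an oxygen on an aromatic ring. Among the measured compounds shown here, no measured step exchanges one substituted phenyl for another on this side chain; the step from compound 1 to compound 2 shows only that altering the group on the saturated chain carbon bound to an oxygen on the aromatic ring moved the number little. Compound 3 is therefore expected to show no change at the digits printed from compound 2 to compound 3 (within the scatter), a step within the scatter. The estimate for compound 3 is 2400 nM, with a range from 1000 nM to 6000 nM.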

Compound 3, half-maximal inhibitory concentration: > 10000 nM
Compound 3: a limit, no number; the forecaster's own chance of this, stated with the estimate: 5%; at least 4.1-fold (0.61 log units) between middle value and limit.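

The value of compound 3 is a limit of the assay and not a number: the limit of > 10000 nM in this assay, at which 1 of the 3 values shown sits.

Even so, the exchange at this place now registers: 3-(trifluoromethyl)phenyl in place of 4-chlorophenyl gives an at least 4.1-fold higher number from compound 2 to compound 3 (0.61 log units; beyond the scatter). Set against ethynyl, the same group gives an at least 2.2-fold higher number from compound 1 to compound 3 (0.34 log units; beyond the scatter), so the group on the saturated chain carbon bound to an oxygen on an aromatic ring, which had barely separated compound 1 and compound 2, sets compound 3 apart from both.

The compounds shown leave open whether the step follows the trifluoromethyl group itself or its place on the ring, a question that a 3-chlorophenyl or a 4-(trifluoromethyl)phenyl group would settle. On these data alone, how a plain phenyl, or a phenyl carrying an amine or a carboxylic acid, would read in this assay also remains open.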